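Ethyl ester of a carboxylic acid: a repeated change

The source may report more compounds than this note shows. Statements on the series, on what has been measured and on what is new or still open speak of the compounds shown alone.

Compound 1, `O=C(O)c1cnc(-c2ccccc2Cl)[nH]c1=O`: in a functional assay on the whole organism (strain Sprague-Dawley) for inhibition, with Rattus norvegicus as the target, with a stated time of 10 min (a lower number here means that less compound is needed, a higher number that more compound is needed for the effect), compound 1 gives 5 mg/kg.
Compound 2, `CCOC(=O)c1cnc(-c2ccccc2Cl)[nH]c1=O`: in this assay compound 2 gives 5 mg/kg.
Compound 3, `COc1nc(-c2ccccc2)ncc1C(=O)O`: in this assay compound 3 reaches only a limit of the assay, > 10 mg/kg.

Compound 1 and compound 2 differ by one change, (ethyl in place of hydrogen on an oxygen next to a carbonyl group), and the step it made is no change at the digits printed from compound 1 to compound 2 (within the scatter). Compound 4, `CCOC(=O)c1cnc(-c2ccccc2)nc1OC`, is not yet measured; it differs from compound 3 by ethyl in place of hydrogen on an oxygen next to a carbonyl group, the same change at the same place. The difference between the core of compound 3 and the core of compound 1 is not broken down here. For compound 3 only a limit is known, (the limit of > 10 mg/kg in this assay, at which 1 of the 3 values shown sits), so no number stands on the side from which the new step starts.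

The step from compound 3 to compound 4 in this assay is expected to be a step that the limit leaves unreadable from compound 3 to compound 4, resting on the earlier step of no change at the digits printed from compound 1 to compound 2 (within the scatter), where the same change left the value where it was. Compound 4 is therefore expected to give about 15 mg/kg, most likely between 5 mg/kg and 50 mg/kg, and it may well again show only a limit.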

Compound 4, dose for 50% inhibition: > 5 mg/kg
Compound 4 gave a limit, no number; the forecaster's own chance of this, stated with the estimate: 65%; the middle value is on the limit's open side.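

In this assay compound 3 and compound 4 each give only a limit of the assay, not a number, so the step between them cannot be read. The compounds shown leave open whether ethyl in place of hydrogen on an oxygen next to a carbonyl group changes the dose needed on the core of compound 3.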